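Moving the chlorine: from compound 3 to compound 4

A few compounds are considered here, and "the series" means these few. Any claim that something is new, unique, unknown or untested is made for them only; others in the source may bear on it.

Compound 3 `NC1=NC2(CCSCC2)N(OCCCOc2ccccc2Cl)C(N)=N1` gives the lowest number of the three measured compounds in a functional assay on HepG2 cells (Homo sapiens) for antiproliferative activity, read by MTT assay, with a stated time of 72 h (a higher number here means a weaker inhibitor, a lower number a stronger inhibitor), at 80 nM. Compound 1 `NC1=NC2(CCSCC2)N(OCCCOc2ccc(Cl)cc2)C(N)=N1` gives 1100 nM and compound 2 `NC1=NC2(CCSCC2)N(OCCCOc2ccc(Br)cc2)C(N)=N1` gives 1400 nM; the change a 1.3-fold higher number from compound 1 to compound 2 (0.10 log units; within the scatter) shows that exchanging one halogen for the other hardly matters here. The steps of a 14-fold lower number from compound 1 to compound 3 (1.14 log units; beyond the scatter) and an 18-fold lower number from compound 2 to compound 3 (1.24 log units; beyond the scatter) were large. Compound 4 `NC1=NC2(CCSCC2)N(OCCCOc2ccc(Cl)c(Cl)c2)C(N)=N1` differs from compound 3 by 3,4-dichlorophenyl in place of 2-chlorophenyl on an oxygen on a saturated carbon. Compound 4 no longer carries the 2-chlorophenyl that set compound 3 apart, while its 3,4-dichlorophenyl resembles the 4-chlorophenyl of compound 1, so much of that large step is expected to be undone. Compound 4 is therefore expected to give 600 nM in this assay, between 150 nM and 2500 nM, a step of a 7.5-fold higher number from compound 3 to compound 4 (0.88 log units; beyond the scatter).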

Compound 4, half-maximal inhibitory concentration: 70 nM
Estimate against measurement, compound 4: 8.6-fold (0.93 log units) above, and the stated range ends above it.
By their numbers in this assay, from the lowest: compounds 4 and 3 (each within the scatter of the next); then compounds 1 and 2 (each within the scatter of the next).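

In this assay, chloro in place of hydrogen on an aromatic carbon gives a 16-fold lower number from compound 1 to compound 4 (1.20 log units; beyond the scatter), and replacing the 4-bromophenyl gives a similar gain, a 20-fold lower number from compound 2 to compound 4 (1.30 log units; beyond the scatter). So 2-chlorophenyl is not alone in reaching the low numbers: the step of a 1.1-fold lower number from compound 3 to compound 4 (0.06 log units; within the scatter) leaves 3,4-dichlorophenyl level with it. Nothing available explains why the second chloro counts for so much. Still open, on these data alone, is whether a methoxy or trifluoromethyl group on the ring could stand in for chloro. Also open, as far as these compounds go, is whether a longer chain between the core and the ring keeps these numbers.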